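Amino for nitro on a hydroxyflavone pair, cytotoxicity

The source may hold more compounds than are shown below. What is called first, only, known or untested is meant among the compounds shown, and "the series" means these compounds.

Measured so far, in a functional assay on Malme-3M cells (Homo sapiens) for cytotoxicity, read by MTT assay, with a stated time of 6 days; on this read-out lower numbers stand for an effect already at smaller amounts and higher numbers for an effect only at larger amounts of compound:

compound 1 `O=c1cc(-c2ccc([N+](=O)[O-])cc2)oc2ccc(O)cc12` gives a limit, > 25 ug/mL.
compound 2 `O=c1cc(-c2ccc([N+](=O)[O-])cc2)oc2cc(O)ccc12` gives a limit, > 25 ug/mL.
compound 3 `Nc1ccc(-c2cc(=O)c3cc(O)ccc3o2)cc1` gives a limit, > 25 ug/mL.

Compound 1 and compound 2 share the same atoms joined differently; the difference between the two cores is not broken down here. Compound 3 comes from compound 1 by amino in place of nitro on an aromatic carbon. The step that the two limits leave unreadable from compound 1 to compound 3 cannot be read, since both ends are limits. Going by the values given here, the only evidence on the measured values is the limit of > 25 ug/mL in this assay, at which 3 of the 3 values shown sit, so no step in this set has a readable size.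

Compound 4 `Nc1ccc(-c2cc(=O)c3ccc(O)cc3o2)cc1` is not yet measured in this assay. It comes from compound 2 by amino in place of nitro on an aromatic carbon, the same change as from compound 1 to compound 3, made on the other core. For compound 2 only a limit is known, and the earlier step is unreadable, so the expectation for compound 4 rests on all three measured values sitting at the limit (the limit of > 25 ug/mL in this assay, at which 3 of the 3 values shown sit). Compound 4 is expected to give 40 ug/mL, within 15 ug/mL to 120 ug/mL, most likely reported as a limit. The step that the limit leaves unreadable from compound 2 to compound 4 is the estimated size, beside the unreadable earlier one, of the same change.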

Compound 4, concentration for half-maximal effect: > 25 ug/mL
Compound 4: only a limit was reported; the forecaster's own chance of this, stated with the estimate: 80%; the middle value lies beyond the limit too.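

Compound 4 gives > 25 ug/mL in this assay as a limit, not a number. Compound 2 is also only a limit, so no new step can be read between compound 2 and compound 4: the limit of > 25 ug/mL in this assay, at which 4 of the 4 values shown sit.

The compounds shown leave open whether amino in place of nitro on an aromatic carbon changes the effect on either core, and whether the two cores differ at all.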